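Hydroxy-nitrobenzamides on liver cells: one trifluoromethyl removed

A few compounds are considered here, and "the series" means these few. Any claim that something is new, unique, unknown or untested is made for them only; others in the source may bear on it.

Compound 1 `O=C(Nc1cccc(C(F)(F)F)c1)c1cccc([N+](=O)[O-])c1O`, compound 2 `O=C(Nc1cc(C(F)(F)F)cc(C(F)(F)F)c1)c1cccc([N+](=O)[O-])c1O` and compound 3 `O=C(Nc1cc(C(F)(F)F)cc(C(F)(F)F)c1)c1ccc([N+](=O)[O-])cc1O` were tested in an ADME assay on HepG2 cells (Homo sapiens) for cytotoxicity, read by MTT assay, with a stated time of 24 h; a higher number here means a weaker inhibitor, a lower number a stronger inhibitor. In this assay compound 1 gives 8900 nM, compound 2 gives 7400 nM and compound 3 gives 4400 nM. The core of compound 3 and the core of compound 2 differ, but that difference is not broken down here. Compound 1 arises from compound 2 by the change (hydrogen in place of trifluoromethyl on an aromatic carbon), which made a step of a 1.2-fold higher number from compound 2 to compound 1 (0.08 log units; within the scatter). Compound 4 `O=C(Nc1cccc(C(F)(F)F)c1)c1ccc([N+](=O)[O-])cc1O`, not yet measured, arises from compound 3 by the same change, (hydrogen in place of trifluoromethyl on an aromatic carbon). Since the earlier step stayed small, the step from compound 3 to compound 4 is expected to be a 1.2-fold higher number from compound 3 to compound 4 (0.08 log units; within the scatter). Compound 4 is therefore estimated at 5300 nM, with a range from 2500 nM to 11000 nM.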

Compound 4, half-maximal inhibitory concentration: 2800 nM
Compound 4: the middle estimate sits 1.9-fold (0.28 log units) above what was measured; low and high end bracket the measured number.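

In this assay the change from trifluoromethyl to hydrogen gives a 1.6-fold lower number from compound 3 to compound 4 (0.20 log units; within the scatter). Set beside the earlier step, this shows that the two cores cannot be told apart in how they respond to the change, so the opposite directions of the two steps should not be read as a real difference: the same change on two cores in this assay, a 1.2-fold higher number (0.08 log units; within the scatter) from compound 2 to compound 1 and a 1.6-fold lower number (0.20 log units; within the scatter) from compound 3 to compound 4, 1.9-fold (0.28 log units) apart, within the scatter of two such steps. It does not show that the change has no effect on every core in the series, and steps this small could hide a modest difference between these two cores.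

The compounds shown leave open how a different group in the same place, such as a chlorine atom, a methoxy group or an amine, would behave on either core. From the compounds shown here alone, whether any such replacement would give a step beyond the scatter also remains open.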